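A Larger Alkyl Group on the Fused Ring of Compound 2

This account rests on a few compounds, and the source may have more. Where it says the series, first, only, none or still open, it means among the compounds named here.

Three compounds share a core built around a benzyl-linked biphenyl bearing a tetrazole. Compound 1 `CCCC1N(Cc2ccc(-c3ccccc3-c3nn[nH]n3)cc2)C(=O)c2ccccc2N1C` carries a propyl chain and a methyl on the ring nitrogen; in an assay on adrenal cortex for inhibition of angiotensinogen (Rattus norvegicus) (a lower number here means a stronger inhibitor, a higher number a weaker inhibitor), compound 1 gives 540 nM. Compound 2 `CCC1Nc2ccc(C)cc2C(=O)N1Cc1ccc(-c2ccccc2-c2nn[nH]n2)cc1` carries an ethyl chain and a methyl on the fused benzene ring; in this assay compound 2 gives 13000 nM. Compound 3 `CCCCC1Nc2ccccc2C(=O)N1Cc1ccc(-c2ccccc2-c2nn[nH]n2)cc1` carries a butyl chain and no substituent on that ring; in this assay compound 3 gives 14000 nM.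

Among the three numbers, compound 2 stands second highest: its value and that of compound 3 lie within the scatter of each other, so no order between them can be claimed, while compound 1 sits far lower, beyond the scatter.

Compound 4 `CCC1Nc2ccc(C(C)C)cc2C(=O)N1Cc1ccc(-c2ccccc2-c2nn[nH]n2)cc1` differs from compound 2 in one place: isopropyl in place of methyl on an aromatic carbon. Going by the values given here, no measured pair shows this change, so its effect in this assay is unknown. The swap keeps the same position and the same absence of donors, acceptors and charge, only adding two carbons, so the expected step is small, in no firm direction, and likely within the scatter.

For compound 4 the value in this assay is estimated at 10000 nM, between 3000 nM and 40000 nM, which means an expected step of a 1.3-fold lower number from compound 2 to compound 4 (0.11 log units; within the scatter).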

Compound 4, half-maximal inhibitory concentration: 90 nM
Compound 4: the middle estimate sits 110-fold (2.05 log units) above what was measured, outside the stated range (below it).
By their numbers in this assay, from the lowest: compound 4; then compound 1; then compounds 2 and 3 (each within the scatter of the next).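

Replacing methyl with isopropyl on this aromatic carbon gives a 140-fold lower number from compound 2 to compound 4 (2.16 log units; beyond the scatter) in this assay, a large move from a single change. The earlier compounds shown here offered no measured step at this position, so they could not show that it matters; this pair shows that it can, even though the group only grows from 1 heavy atom to 3 heavy atoms and neither group has a hydrogen-bond donor, a hydrogen-bond acceptor or a net charge. Nothing at hand explains why so small a change has so large an effect.

Going by these compounds alone, with only this one pair at the position, it remains open whether the large step is particular to isopropyl or would also appear with other groups on the same carbon, such as a tert-butyl, a cyclopropyl, a methoxy or an amine. Also open, from the compounds shown here alone, is whether isopropyl on this carbon would have a similar effect alongside a butyl chain, as in compound 3, rather than the ethyl chain of compound 4.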